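Triazole diaryl series: halogen-to-trifluoromethyl swap on the N-aryl ring

The compounds below may be only part of what the source reports. "The series", "measured", "known", "first", "only" and "open" are said of these compounds alone.

Of the compounds shown here, three have been measured so far. Compound 1 `Oc1cc(C(F)(F)F)ccc1-c1nc(-c2ccccc2O)n(-c2ccc(Cl)cc2)n1` gives 68% in a functional assay on PC-12 cells (Rattus norvegicus) for cytotoxicity, read by MTT assay, with stated times of 2 h and 24 h, tested at 1 uM; on this read-out lower numbers stand for a weaker effect and higher numbers for a stronger effect at the one concentration tested. Compound 2 `Oc1cc(C(F)(F)F)ccc1-c1nc(-c2ccccc2O)n(-c2ccc(C(F)(F)F)cc2)n1` gives 70.7% in this assay, and compound 3 `Oc1cc(C(F)(F)F)ccc1-c1nc(-c2ccccc2O)n(-c2ccccc2Cl)n1` gives 70.1% in this assay.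

The change from compound 1 to compound 2 is trifluoromethyl in place of chloro on an aromatic carbon and moved the read-out by a number 2.7 percentage points higher from compound 1 to compound 2 (within the scatter). The cores of compound 1 and compound 3 differ by 2-chlorophenyl in place of 4-chlorophenyl on an aromatic nitrogen, and that change gave a number 2.1 percentage points higher from compound 1 to compound 3 (within the scatter). Between compound 2 and compound 3 the difference is a number 0.6 percentage points lower from compound 2 to compound 3 (within the scatter). All three numbers sit close together, and none of the steps between them separates from the scatter of repeated measurements.

Compound 4 `Oc1cc(C(F)(F)F)ccc1-c1nc(-c2ccccc2O)n(-c2ccccc2C(F)(F)F)n1` is not yet measured. It differs from compound 3 by trifluoromethyl in place of chloro on an aromatic carbon. Going by the values given here, this is the same kind of change as the one from compound 1 to compound 2, but not the same: in compound 2 the entering group stands para to a large group, whereas in compound 4 it stands ortho to a large group. Among the compounds with values here, the step is expected to be small, a number 1.9 percentage points higher from compound 3 to compound 4 (within the scatter), because the only measured instance of this kind of change gave a number 2.7 percentage points higher from compound 1 to compound 2 (within the scatter). The value of compound 4 in this assay is therefore estimated at 72%, with an expected range from 64% to 80%.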

Compound 4, a percentage reported as activity, at one concentration (the size of the read-out at that concentration, not a potency): 71%
Compound 4: the middle estimate sits 1 percentage points above what was measured; measured number inside the range.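

The new step for trifluoromethyl in place of chloro on an aromatic carbon is a number 0.9 percentage points higher from compound 3 to compound 4 (within the scatter) in this assay, and it compares with the earlier one as follows: the same change on two cores in this assay, a number 2.7 percentage points higher (within the scatter) from compound 1 to compound 2 and a number 0.9 percentage points higher (within the scatter) from compound 3 to compound 4, 1.8 percentage points apart, within the scatter of two such steps The two steps that exchange the whole aryl group on nitrogen, a number 0.3 percentage points higher from compound 2 to compound 4 (within the scatter) and a number 3 percentage points higher from compound 1 to compound 4 (within the scatter), also leave all four compounds undivided by the read-out. This shows that on these two pairs the change carries from the 4-substituted to the 2-substituted aryl compounds without a step that separates from the scatter; it does not show a real effect of the change on either core, nor that the same would hold on a core carrying other groups.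

All four compounds share the two hydroxyl-bearing aryl rings and differ only in a chloro or trifluoromethyl group on the aryl ring on nitrogen. Going by these compounds, whether an amine, a carboxylic acid or a longer alkyl chain on that ring would move the number in this assay beyond the scatter stays open, as does the behaviour of this series at any other concentration.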